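Replacing Amino with 2-Methylphenyl on Compound 3

A few compounds are considered here, and "the series" means these few. Any claim that something is new, unique, unknown or untested is made for them only; others in the source may bear on it.

Compound 3 `Cc1c(-n2c(-c3ccccc3)c(-c3ccccc3)c3c(NN)ncnc32)n(C)n(-c2ccccc2)c1=O` gives 65.1% in a functional assay on the whole organism (strain Sprague-Dawley) for inhibition, with Rattus norvegicus as the target, read by paw edema, with stated times of 1 h and 3 h, at a dose of 70 mg/kg by the subcutaneous route (on this read-out lower numbers stand for less inhibition and higher numbers for more inhibition at the one dose given (going by the name of the read-out)), the second highest of the three measured numbers. Compound 2 `Cc1c(-n2c(-c3ccccc3)c(-c3ccccc3)c3c(N/N=C/c4ccccc4)ncnc32)n(C)n(-c2ccccc2)c1=O` gives 90.8%, the step of a number 25.7 percentage points lower from compound 2 to compound 3 (beyond the scatter) lying beyond the scatter, while compound 1 `Cc1c(-n2c(-c3ccccc3)c(-c3ccccc3)c3c(Nc4ccccc4)ncnc32)n(C)n(-c2ccccc2)c1=O` gives 13%, far below both. Compound 4 `Cc1ccccc1Nc1ncnc2c1c(-c1ccccc1)c(-c1ccccc1)n2-c1c(C)c(=O)n(-c2ccccc2)n1C` is compound 3 with 2-methylphenyl in place of amino on a nitrogen on an aromatic ring. The measured step that bears on this change is a number 52.1 percentage points higher from compound 1 to compound 3 (beyond the scatter), in which phenyl gave way to amino on that nitrogen; compound 4 runs that step back, with 2-methylphenyl rather than phenyl entering. Compound 4 is therefore expected to drop to near compound 1, a step of a number 45.1 percentage points lower from compound 3 to compound 4 (beyond the scatter). The estimate for compound 4 is 20%, with a range from 5% to 45%.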

Compound 4, a percentage reported as inhibition, in the whole organism at one dose (the size of the read-out at that dose, not a potency): 13.3%
Compound 4: the middle estimate sits 6.7 percentage points above what was measured; the range from low to high includes it.
By their numbers in this assay, from the lowest: compounds 1 and 4 (each within the scatter of the next); then compound 3; then compound 2.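

The new result shows that, on this nitrogen, adding a methyl to the phenyl group leaves the reading in this assay unchanged, with methyl in place of hydrogen on an aromatic carbon giving a number 0.3 percentage points higher from compound 1 to compound 4 (within the scatter). The 2-methylphenyl group thus carries the same large penalty as phenyl, seen as a number 51.8 percentage points lower from compound 3 to compound 4 (beyond the scatter) and as a number 77.5 percentage points lower from compound 2 to compound 4 (beyond the scatter). Nothing available explains these steps.

On these data alone, it remains open how a methylamino or acetyl group would read on that nitrogen. Also open, as far as these compounds go, is whether a chlorine or methoxy group on the phenyl ring would read as low.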